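Benzyl in Place of Pyridin-4-yl on a Ring Nitrogen

The source may hold more compounds than are shown below. What is called first, only, known or untested is meant among the compounds shown, and "the series" means these compounds.

Measured so far:
compound 1, `Nc1ccccc1NC(=O)c1ccc(CSC(=S)N2CCN(c3ccccc3)CC2)cc1`: 62.2%
compound 2, `Nc1ccccc1NC(=O)c1ccc(CSC(=S)N2CCN(c3ccncc3)CC2)cc1`: 77%

Two compounds share one core and differ only in the group carried on an amine nitrogen in a ring. In a functional assay on HeLa cells (Homo sapiens) for antiproliferative activity, read by CCK-8 assay, with a stated time of 72 h, tested at 2 uM (on this read-out lower numbers stand for a weaker effect and higher numbers for a stronger effect at the one concentration tested), compound 1 gives 62.2%, and compound 2 gives 77%. Among the compounds with values here, the single step known here is a number 14.8 percentage points higher from compound 1 to compound 2 (beyond the scatter). Compound 2 thus stands highest of the two numbers, with compound 1 the nearest and lower by a margin beyond the scatter.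

Compound 3, `Nc1ccccc1NC(=O)c1ccc(CSC(=S)N2CCN(Cc3ccccc3)CC2)cc1`, is the next compound and has not yet been measured. It differs from compound 2 as follows: benzyl in place of pyridin-4-yl on an amine nitrogen in a ring. Within the data shown here, no measured step compares benzyl with any other group on this nitrogen, so the one step that exists only shows how much this position can move the read-out when the group is exchanged, not where benzyl will land. Among the measured compounds shown here, the expectation therefore sits between the two known numbers rather than beyond them. For compound 3 in this assay the estimate is 62%, with a range from 42% to 80%. Relative to compound 2 this expected change amounts to a number 15 percentage points lower from compound 2 to compound 3 (beyond the scatter).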

Compound 3, a percentage reported as inhibition, at one concentration (the size of the read-out at that concentration, not a potency): 20.6%
Estimate against measurement, compound 3: 41.4 percentage points above; measured number outside the range, below it.
By their numbers in this assay, from the lowest: compound 3; then compound 1; then compound 2.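

In this assay the group on this amine nitrogen proves able to do far more than the earlier pair suggested: benzyl in place of pyridin-4-yl gives a number 56.4 percentage points lower from compound 2 to compound 3 (beyond the scatter) and benzyl in place of phenyl gives a number 41.6 percentage points lower from compound 1 to compound 3 (beyond the scatter) and so leaves compound 3 the weakest of the three at the one concentration tested. The second step is the more telling one, since benzyl carries the same six-membered aromatic ring of carbon only as phenyl, and the two groups differ in that benzyl joins its ring to the nitrogen through a carbon link rather than directly, so a small change in how the ring is attached goes with a large loss in the read-out. Nothing measured for these compounds accounts for the size of this loss.

The compounds shown leave open whether a longer chain such as phenethyl would lower the number further, and whether pyridin-4-ylmethyl, which puts the ring of compound 2 on the same carbon link, would win any of it back. They also give no view of a carbonyl-linked group such as benzoyl, or of a small alkyl group such as methyl, on this nitrogen.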